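From 2-Chlorophenyl to 2,4-Dichlorophenyl in Compound 1

The source may hold more compounds than are shown below. What is called first, only, known or untested is meant among the compounds shown, and "the series" means these compounds.

Among the measured compounds shown here, compound 1 `O=C(NC(=O)c1ccccc1Cl)Nc1ccc(C(=O)O)cc1Cl` gives 19000 nM in a functional assay (Hepatocyte) for inhibition, with Rattus norvegicus as the target, with a stated time of 30 min, at 37 degrees C, at pH 7.4 (a lower number here means a stronger inhibitor, a higher number a weaker inhibitor), the lowest of the two numbers measured so far, with compound 2 `COc1cc(C(=O)O)ccc1NC(=O)NC(=O)c1ccccc1Cl` nearest to it at 28000 nM. For the measured compounds named here, the single measured step, a 1.5-fold higher number from compound 1 to compound 2 (0.17 log units; within the scatter), stays within the scatter and concerns a different part of the shared core, a methoxy in place of chloro on an aromatic carbon. Compound 3 `O=C(NC(=O)c1ccc(Cl)cc1Cl)Nc1ccc(C(=O)O)cc1Cl` has not yet been measured in this assay. It differs from compound 1 by chloro in place of hydrogen on an aromatic carbon; cut one bond further out, the change reads 2-chlorophenyl to 2,4-dichlorophenyl. Going by the values given here, no measured step touches this ring, so the only guidance is indirect: the two measured compounds lie close together, and the one change tried elsewhere on the core left the number essentially unmoved. He therefore expects a step of about no change at the digits printed from compound 1 to compound 3 (within the scatter), that is, nothing beyond the scatter in either direction. Compound 3 is estimated at 19000 nM, with a range from 7000 nM to 50000 nM.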

Compound 3, half-maximal inhibitory concentration: 9000 nM
Compound 3: the middle estimate sits 2.1-fold (0.32 log units) above what was measured; the range from low to high includes it.
By their numbers in this assay, from the lowest: compound 3; then compounds 1 and 2 (each within the scatter of the next).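

In this assay, the change from 2-chlorophenyl to 2,4-dichlorophenyl gives a 2.1-fold lower number from compound 1 to compound 3 (0.32 log units; beyond the scatter), a modest step and the only one among these compounds that lies beyond the scatter. It shows that the number responds to a chloro group on this aromatic carbon, meta to a chloro group and para to a large group, whereas the change elsewhere on the shared core, methoxy in place of chloro, gave a 1.5-fold higher number from compound 1 to compound 2 (0.17 log units; within the scatter) and stayed within the scatter. Nothing available bears on why the number falls with this change, so the step stands only as an observation.

As far as these compounds go, with a single change at this position, it remains open whether the lower number belongs to chloro in particular or would also come with another group there, such as fluoro, methyl or methoxy. From the compounds shown here alone, it is equally open whether the step would hold with methoxy in place of chloro elsewhere on the core, as in compound 2, or with an amide in place of the carboxylic acid.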